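A Second Fluorine on the Acid-Bearing Carbon

The compounds below may be only part of what the source reports. "The series", "measured", "known", "first", "only" and "open" are said of these compounds alone.

The series shares a single core, shown in compound 1 `COc1ccc(F)c([C@H]2CC[C@H](COc3cccc([C@H](C4CC4)[C@H](F)C(=O)O)c3)CC2)c1`, and varies only the group on a saturated chain carbon bound to an aromatic carbon and a saturated ring carbon. In a functional assay on HEK293 cells for agonist activity at Free fatty acid receptor 1 (Homo sapiens), read by FLIPR and calcium flux (on this read-out lower numbers stand for an effect already at smaller amounts and higher numbers for an effect only at larger amounts of compound), compound 1 gives 54 nM, the highest number of the three measured compounds. Compound 2 `COc1ccc(F)c([C@H]2CC[C@H](COc3cccc([C@H](C4CC4)[C@](C)(F)C(=O)O)c3)CC2)c1` gives 6.1 nM in this assay, and compound 3 `COc1ccc(F)c([C@H]2CC[C@H](COc3cccc([C@H](C4CC4)C(C)(C)C(=O)O)c3)CC2)c1` gives 0.11 nM.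

Compound 4 `COc1ccc(F)c([C@H]2CC[C@H](COc3cccc([C@H](C4CC4)C(F)(F)C(=O)O)c3)CC2)c1` has not been measured. It differs from compound 1 by carboxy(difluoro)methyl in place of carboxy(fluoro)methyl on a saturated chain carbon bound to an aromatic carbon and a saturated ring carbon.

Within the data shown here, two measured steps bear on this change. The step of an 8.9-fold lower number from compound 1 to compound 2 (0.95 log units; beyond the scatter) shows that a second substituent on that carbon, a methyl beside the fluorine, lowers the number. The step of a 55-fold lower number from compound 2 to compound 3 (1.74 log units; beyond the scatter) shows that methyl in place of fluorine on the same carbon lowers it far more, so fluorine is the weaker of the two partners in these data. A second fluorine is therefore expected to give at most a modest lowering, possibly none beyond the scatter.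

Compound 4 is estimated at 25 nM in this assay, with a range from 6 nM to 110 nM. This estimate corresponds to an expected step of a 2.2-fold lower number from compound 1 to compound 4 (0.33 log units; beyond the scatter).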

Compound 4, half-maximal effective concentration: 16 nM
Estimate against measurement, compound 4: 1.6-fold (0.19 log units) above; the measured number falls inside the stated range.
By their numbers in this assay, from the lowest: compound 3; then compound 2; then compound 4; then compound 1.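

In this assay, a second fluorine on the saturated chain carbon bound to an aromatic carbon and a saturated ring carbon does lower the number, with a 3.4-fold lower number from compound 1 to compound 4 (0.53 log units; beyond the scatter) as a modest step, so all three compounds carrying a second substituent on that carbon now sit below compound 1, and none goes against this. The partner still matters: replacing the methyl of the 1-carboxy-1-fluoroethyl group with fluorine gives a 2.6-fold higher number from compound 2 to compound 4 (0.42 log units; beyond the scatter), whereas carboxy(difluoro)methyl in place of 1-carboxy-1-methylethyl gives a 150-fold higher number from compound 3 to compound 4 (2.16 log units; beyond the scatter), so the two fluorines recover only a small part of what the two methyls reach. The change also removes the one defined stereocentre of the carboxy(fluoro)methyl group, yet the number still falls, and nothing shown here accounts for any of these differences.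

The compounds shown leave open how a chlorine, a hydroxyl or a methoxy group would behave as the partner on that carbon, and whether a cyclopropane ring closed on it would match the two methyls. They also leave open how the opposite configuration of the carboxy(fluoro)methyl carbon would compare with compound 1 and compound 4.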